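From Trimethoxyphenyl to Hydroxymethylphenyl: A Small Expected Step

A few compounds are considered here, and "the series" means these few. Any claim that something is new, unique, unknown or untested is made for them only; others in the source may bear on it.

In an ADME assay on cells (Peritoneal macrophage, Mus musculus, strain Balb/c) for cytotoxicity, read by resazurin assay, with a stated time of 72 h (on this read-out higher numbers stand for lower toxicity in this test and lower numbers for higher toxicity in this test), compound 1 `CC1(Cc2ccccc2C(F)(F)F)CC(S(=O)(=O)c2ccc(F)cc2)=C(c2ccc(/C(N)=N/O)cc2)O1` gives 105000 nM, compound 2 `CC1(Cc2cccc([N+](=O)[O-])c2)CC(S(=O)(=O)c2ccc(F)cc2)=C(c2ccc(/C(N)=N/O)cc2)O1` gives 86600 nM and compound 3 `COc1cc(CC2(C)CC(S(=O)(=O)c3ccc(F)cc3)=C(c3ccc(/C(N)=N/O)cc3)O2)cc(OC)c1OC` gives 92300 nM. Compound 3 therefore stands level with the other two, within the scatter of both. Compound 4 `CC1(Cc2cccc(CO)c2)CC(S(=O)(=O)c2ccc(F)cc2)=C(c2ccc(/C(N)=N/O)cc2)O1` carries 3-(hydroxymethyl)phenyl in place of 3,4,5-trimethoxyphenyl on a saturated chain carbon bound to a saturated ring carbon. Three measured swaps at this same place bear on it: a 1.2-fold lower number from compound 1 to compound 2 (0.08 log units; within the scatter), a 1.1-fold lower number from compound 1 to compound 3 (0.06 log units; within the scatter) and a 1.1-fold higher number from compound 2 to compound 3 (0.03 log units; within the scatter). All three lie within the scatter, so no step beyond it is expected in this assay, although no hydroxymethyl group has been measured yet. The expected step is a 1.0-fold lower number from compound 3 to compound 4 (0.01 log units; within the scatter). For compound 4 the estimated value is 90000 nM, with an expected range from 50000 nM to 150000 nM.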

Compound 4, half-maximal cytotoxic concentration: > 100000 nM
Compound 4 ended at the assay's limit (the forecaster's own chance of this, stated with the estimate: 10%); middle value at least 1.1-fold (0.04 log units) away from the limit.
By their numbers in this assay, from the lowest: compounds 2, 3 and 1 (each within the scatter of the next).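

In this assay compound 4 gives > 100000 nM as a limit of the assay, not a number. Even with the hydrogen-bond donor of 3-(hydroxymethyl)phenyl, this place tolerates the change without a lower number: there is an at least 1.0-fold higher number from compound 3 to compound 4 (0.03 log units; that floor lies within the scatter) and an at least 1.1-fold higher number from compound 2 to compound 4 (0.06 log units; that floor lies within the scatter), and both floors are small. The step involving compound 1 cannot be read. On these data alone, how far the true value of compound 4 lies past the limit remains open, as does whether an amine or a carboxylic acid at this place would finally move the number beyond the scatter.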